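From thiophen-3-yl to cyclopropyl at the solubility ceiling

The source may hold more compounds than are shown below. What is called first, only, known or untested is meant among the compounds shown, and "the series" means these compounds.

Compound 2 `CN1CCC(C(=O)N2Cc3c(NC(=O)c4ccsc4)n[nH]c3C2(C)C)CC1` shares its core with compound 1 `CC(C)(C)C(=O)N1Cc2c(NC(=O)c3ccncc3)n[nH]c2C1(C)C` and compound 3 `CN(C)CC(=O)Nc1n[nH]c2c1CN(C(=O)C(C)(C)C)C2(C)C`. In a physicochemical assay for solubility, at pH 7 (on this read-out higher numbers stand for higher solubility and lower numbers for lower solubility), compound 1 gives 205000 nM. Compound 3 gives > 225000 nM, which is a limit of the assay rather than a number. Compound 2 in turn gives > 225000 nM in this assay, again a limit and not a number. Compound 2 thus stands at the ceiling of what this assay reports, namely (the limit of > 225000 nM in this assay, at which 2 of the 3 values shown sit). Compound 4 `CN1CCC(C(=O)N2Cc3c(NC(=O)C4CC4)n[nH]c3C2(C)C)CC1` differs from compound 2 by cyclopropyl in place of thiophen-3-yl on a carbonyl carbon. Among the compounds with values here, no measured step covers this change directly. Within the data shown here, the only measured step, an at least 1.0-fold higher number from compound 1 to compound 3 (0.04 log units; that floor lies within the scatter), concerns a different change on the same carbonyl carbon and lies within the scatter, with compound 3 ending at the limit. Because both compound 2 and compound 3 sit at the limit of > 225000 nM in this assay, at which 2 of the 3 values shown sit, a reading of compound 4 beyond that limit cannot be ruled out from the numbers shown. The step of a number no higher from compound 2 to compound 4 (the limit leaves the size open) is therefore expected to be small, not beyond the scatter. Compound 4 is estimated at 225000 nM in this assay, within 110000 nM to 400000 nM, with a fair chance that only a limit is again reported.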

Compound 4, solubility: > 225000 nM
Compound 4 gave a limit, no number; the forecaster's own chance of this, stated with the estimate: 60%; the middle value sits exactly at the limit.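

Compound 2 and compound 4 both sit at a limit rather than a number in this assay, so no step can be read between them: the limit of > 225000 nM in this assay, at which 3 of the 4 values shown sit. The compounds shown leave open how far each lies past that limit, and whether the two differ at all.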